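The source may report more compounds than this note shows. Statements on the series, on what has been measured and on what is new or still open speak of the compounds shown alone.

Measured in a functional assay on HL-60 cells (Homo sapiens) for inhibition, read by MTT assay, with a stated time of 72 h; on this read-out lower numbers stand for stronger inhibition and higher numbers for weaker inhibition:
- compound 1, `C#CCO[C@@H]1C=CC(=O)[C@@H](CO)O1`: 9300 nM
- compound 2, `C=CCO[C@@H]1C=CC(=O)[C@@H](CO)O1`: 4900 nM
- compound 3, `O=C1C=C[C@@H](OCc2ccccc2)O[C@@H]1CO`: 27300 nM

Compound 1 gives the second highest of the three numbers in this assay; the nearest value is that of compound 2, which differs from it by a 1.9-fold lower number from compound 1 to compound 2 (0.28 log units; within the scatter), and the furthest is that of compound 3, which sits beyond the scatter. The step to the unmeasured compound 4, `CCCO[C@@H]1C=CC(=O)[C@@H](CO)O1`, is ethyl in place of ethynyl on a saturated chain carbon bound to an oxygen on a saturated carbon; seen one bond further out it reads propargyl to propyl. Going by the values given here, the only measured step at the same place is the one in which vinyl replaces ethynyl, a 1.9-fold lower number from compound 1 to compound 2 (0.28 log units; within the scatter), and it stays within the scatter. Compound 3 shows a higher number, but no single-place comparison to compound 1 is available for it, so it gives no size for the change at hand. The expectation for compound 4 in this assay is therefore a step of no more than a 1.3-fold lower number from compound 1 to compound 4 (0.12 log units; within the scatter), without a clear direction beyond the scatter. Compound 4 is estimated at 7000 nM, with a range from 3000 nM to 20000 nM.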

Compound 4, half-maximal inhibitory concentration: 10700 nM
The estimate for compound 4 lay 1.5-fold (0.18 log units) below the measured number; the range from low to high includes it.
By their numbers in this assay, from the lowest: compounds 2, 1 and 4 (each within the scatter of the next, the first and the last beyond it); then compound 3.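

In this assay, the triple bond of the propargyl group is dispensable at this position: with ethyl in place of ethynyl the step is a 1.2-fold higher number from compound 1 to compound 4 (0.06 log units; within the scatter), so propargyl and propyl cannot be told apart on this read-out. Going by these compounds alone, the change from vinyl to ethyl gives the first step at this place that lies beyond the scatter, a 2.2-fold higher number from compound 2 to compound 4 (0.34 log units; beyond the scatter), though it remains modest and neither compound 2 nor compound 4 separates from compound 1 beyond the scatter. No measured evidence accounts for either step.

Going by these compounds, whether a longer chain such as butyl, or a chain carrying an amine or a carboxylic acid, would stay in the same range remains open. Within the data shown here, no single-place step links compound 3, at 27300 nM, to the other compounds, so the size of any change to benzyl also remains open.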